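The source may hold more compounds than are shown below. What is called first, only, known or untested is meant among the compounds shown, and "the series" means these compounds.

Notes on the series: in a functional assay on THP-1 cells (Homo sapiens) for cytotoxicity, read by MTT assay, with a stated time of 24 h (on this read-out higher numbers stand for weaker inhibition and lower numbers for stronger inhibition), compound 1 (`CN1C/C(=C\c2ccc(C(F)(F)F)cc2)C(=O)/C(=C/c2ccccc2F)C1`) gives 5930 nM and compound 2 (`CN1C/C(=C\c2cccc([N+](=O)[O-])c2)C(=O)/C(=C/c2ccc(Cl)cc2Cl)C1`) gives 3560 nM as its value, while compound 3 (`CN1C/C(=C\c2ccc(F)cc2)C(=O)/C(=C/c2ccc(C#N)cc2)C1`) gives 5030 nM on the same read-out. Compound 3 stands within the scatter of both compound 1 and compound 2, although the substituents differ among all three.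

Compound 4 (`CN1C/C(=C\c2ccc(Br)cc2)C(=O)/C(=C/c2ccc(C#N)cc2)C1`) departs from compound 3 at one place: bromo in place of fluoro on an aromatic carbon with bromo in place of fluoro on an aromatic carbon, para to a large group, which reads as 4-fluorophenyl to 4-bromophenyl. For the measured compounds named here, no measured pair isolates this change, so its size cannot be read directly from the data.

The expectation rests on compound 3 at 5030 nM and is for no step beyond the scatter in this assay in either direction. The expected change is a 1.2-fold lower number from compound 3 to compound 4 (0.08 log units; within the scatter) and would remain within that scatter. For compound 4 the estimated value is 4200 nM with an expected range from 2000 nM to 8500 nM in this read-out.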

Compound 4, half-maximal inhibitory concentration: 4400 nM
Estimate against measurement, compound 4: 1.0-fold (0.02 log units) below; the measured number falls inside the stated range.
By their numbers in this assay, from the lowest: compounds 2, 4, 3 and 1 (each within the scatter of the next).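

In this assay, for the compounds shown here, compounds 3 and 4 form the only pair so far that differs in one place, and a 1.1-fold lower number from compound 3 to compound 4 (0.06 log units; within the scatter) shows that on this aromatic carbon, para to a large group, bromo in place of fluoro leaves the number within the scatter. The earlier compounds shown here differed from one another in more than one place, so they could not separate the contribution of this position; here the 4-fluorophenyl to 4-bromophenyl change is read alone, with the rest of compound 3 held constant. Nothing available bears on the reason for this result.

Going by these compounds, whether a group of another kind at this position, such as an amine or a carboxylic acid, would also stay within the scatter remains open. Also open, on these data alone, is whether the same halogen change gives a similar step on the background of compound 1 or compound 2.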